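Replacing the Amide Substituent of Compound 1

The compounds below may be only part of what the source reports. "The series", "measured", "known", "first", "only" and "open" are said of these compounds alone.

Measured so far:
compound 1, `CCN(CC)CCNC(=O)c1ccc(C(CC)(CC)c2ccc(OCCC(O)(CC)CC)c(C)c2)n1CC`: 230 nM
compound 2, `C=CCN(C)C(=O)c1ccc(C(CC)(CC)c2ccc(OCCC(O)(CC)CC)c(C)c2)n1CC`: > 50000 nM
compound 3, `C#CCCOC(=O)c1ccc(C(CC)(CC)c2ccc(OCCC(O)(CC)CC)c(C)c2)n1CC`: > 50000 nM

Going by the values given here, in a functional assay on HepG2 cells (Homo sapiens) for antiproliferative activity, read by MTT assay, with a stated time of 48 h (a higher number here means a weaker inhibitor, a lower number a stronger inhibitor), compound 1 gives 230 nM, the only actual number in the set. For compound 2 the result is a limit of the assay, > 50000 nM, not a number. For compound 3 the result is likewise a limit, > 50000 nM. Two of the three outcomes therefore sit at the limit of > 50000 nM in this assay, at which 2 of the 3 values shown sit.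

Compound 4, `CCC(C)C(CO)NC(=O)c1ccc(C(CC)(CC)c2ccc(OCCC(O)(CC)CC)c(C)c2)n1CC`, has not been measured. It differs from compound 1 in one place: 1-(hydroxymethyl)-2-methylbutyl in place of 2-(diethylamino)ethyl on an amide-type nitrogen. The measured steps that bear on this are an at least 210-fold higher number from compound 1 to compound 2 (2.33 log units; beyond the scatter) and an at least 210-fold higher number from compound 1 to compound 3 (2.33 log units; beyond the scatter); both replace the same group on the carbonyl carbon and both end at the assay limit. Compound 4 keeps an amide nitrogen bearing a hydrogen, unlike compound 2 and compound 3, so a somewhat smaller loss is conceivable, but the direction should be the same. Compound 4 is expected to show a 65-fold higher number from compound 1 to compound 4 (1.81 log units; beyond the scatter). The estimated value for compound 4 is 15000 nM, with a range from 1500 nM to 60000 nM, and the result may well again be only a limit.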

Compound 4, half-maximal inhibitory concentration: > 50000 nM
Compound 4 gave a limit, no number (the forecaster's own chance of this, stated with the estimate: 45%); middle value at least 3.3-fold (0.52 log units) away from the limit.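

Compound 4 keeps the amide hydrogen that compound 2 and compound 3 lack, and its 1-(hydroxymethyl)-2-methylbutyl group has the same 7 heavy atoms as the 2-(diethylamino)ethyl group it replaces, yet the result is an at least 210-fold higher number from compound 1 to compound 4 (2.33 log units; beyond the scatter). In this assay compound 4 gives > 50000 nM, which is a limit of the assay and not a number. Keeping the amide hydrogen is therefore not enough on its own, and of the compounds shown only compound 1, the one carrying the diethylamino group, gives a number, while the others all stop at the same point: the limit of > 50000 nM in this assay, at which 3 of the 4 values shown sit.

The steps among compound 2, compound 3 and compound 4 cannot be read, as each joins two limits. On these data alone, it remains open whether the amine itself matters or the chain carrying it, which a dimethylamino or piperidine end, or a propyl chain leading to the same diethylamino group, could separate.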